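A few compounds are considered here, and "the series" means these few. Any claim that something is new, unique, unknown or untested is made for them only; others in the source may bear on it.

Three compounds built on the same core have been run in a functional assay on the whole organism (strain Kunming) for inhibition, with Mus musculus as the target, in the writhing test, at a dose of 40 mg/kg by the oral route; a lower number here means less inhibition, a higher number more inhibition at the dose given (going by the name of the read-out). Compound 1 `CC(=O)Oc1ccc(-c2ccc(F)cc2F)cc1C(=O)O` gives 0%. Compound 2 `O=C(Oc1ccc(-c2ccc(F)cc2F)cc1C(=O)O)c1ccccc1`, in which a phenyl sits in place of a methyl on a carbonyl carbon, gives 7.97%; the step of a number 8 percentage points higher from compound 1 to compound 2 (within the scatter) is too small to tell the two apart. Among the measured compounds shown here, compound 3 `CC(=O)Oc1ccc(-c2ccc(F)cc2F)cc1C(=O)NC1CCCCC1`, with cyclohexylamino in place of hydroxy on a carbonyl carbon, gives 15.6%, and the step of a number 15.6 percentage points higher from compound 1 to compound 3 (beyond the scatter) is the one clear change among the measured numbers. Compound 2 thus sits with a value that neither compound 1 nor compound 3 is separated from beyond the scatter.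

The next compound, compound 4 `CCN(CC)C(=O)c1cc(-c2ccc(F)cc2F)ccc1OC(=O)c1ccccc1`, is compound 2 with a single change at the carbonyl carbon: diethylamino in place of hydroxy on a carbonyl carbon. For the measured compounds named here, the only measured step that resembles this change is the one from compound 1 to compound 3, where an amino group replaced the hydroxy on the same carbonyl carbon and this assay rose by a modest, real amount. By the same reasoning a rise of similar size is expected from compound 2 to compound 4, namely a number 12 percentage points higher from compound 2 to compound 4 (beyond the scatter). Compound 4 is therefore estimated to give 20% in this assay, plausibly anywhere from 8% to 35%.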

Compound 4, a percentage reported as inhibition, in the whole organism at one dose (the size of the read-out at that dose, not a potency): 0%
Estimate against measurement, compound 4: 20 percentage points above, and the stated range ends above it.
By their numbers in this assay, from the lowest: compounds 1, 4, 2 and 3 (each within the scatter of the next, the first and the last beyond it).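

In this assay, diethylamino in place of hydroxy on a carbonyl carbon whose other neighbour is an aromatic carbon gives a number 8 percentage points lower from compound 2 to compound 4 (within the scatter), so this change, which turns the carboxy group into diethylcarbamoyl, cannot be told from no change at all. The earlier step, a number 15.6 percentage points higher from compound 1 to compound 3 (beyond the scatter), had suggested that swapping the hydroxy for an amine on this carbonyl carbon brings a real gain, but that gain does not appear here, so it cannot be taken as a general feature of this position. The two steps differ both in the entering amine, cyclohexylamino against diethylamino, and in the other ester group, methyl against phenyl, and no measurement available here explains why the outcomes differ.

Which of those two differences matters remains open, since a compound pairing cyclohexylamino with the phenyl ester, or diethylamino with the methyl ester, would separate them. Also open, on these data alone, is how other amines on this carbonyl carbon, such as methylamino, piperidine or morpholine, would behave on the shared core.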